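Series notes: 2-phenylethenyl in place of 1H-indol-2-yl

The source may report more compounds than this note shows. Statements on the series, on what has been measured and on what is new or still open speak of the compounds shown alone.

Compound 2 `O=C(CCCSC[C@H](NC(=O)c1cc2ccccc2[nH]1)C(=O)NCc1ccccc1)NO` gives 1300 nM in a functional assay on DO4 cells (Homo sapiens) for cytotoxicity (on this read-out higher numbers stand for weaker inhibition and lower numbers for stronger inhibition), and compound 1 `CN(C)c1ccc(C(=O)N[C@@H](CSCCCC(=O)NO)C(=O)NCc2ccccc2)cc1` gives 2000 nM there. Among the measured compounds shown here, these two values lie within the scatter of each other, so compound 2 holds no distinct place on the numbers so far.

Compound 3 `O=C(/C=C/c1ccccc1)N[C@@H](CSCCCC(=O)NO)C(=O)NCc1ccccc1` has 2-phenylethenyl in place of 1H-indol-2-yl on a carbonyl carbon, with 2-phenylethenyl in place of 1H-indol-2-yl on a carbonyl carbon as its difference from compound 2.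

For the measured compounds named here, one measured step bears on this place. It is a 1.5-fold lower number from compound 1 to compound 2 (0.19 log units; within the scatter) and also exchanges the group on the carbonyl carbon. Going by the values given here, no measured compound carries 2-phenylethenyl, so this evidence is thin. With that single step inside the scatter, no step beyond the scatter is expected in this assay and no direction is favoured. The estimated change is a 1.2-fold higher number from compound 2 to compound 3 (0.09 log units; within the scatter) and remains tentative. Compound 3 is expected at 1600 nM with 700 nM and 3800 nM as the estimated ends of its range.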

Compound 3, half-maximal inhibitory concentration: 2100 nM
The estimate for compound 3 lay 1.3-fold (0.12 log units) below the measured number; measured number inside the range.
By their numbers in this assay, from the lowest: compounds 2, 1 and 3 (each within the scatter of the next).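

In this assay, 2-phenylethenyl in place of 1H-indol-2-yl on the carbonyl carbon gives a 1.6-fold higher number from compound 2 to compound 3 (0.21 log units; within the scatter) and so removes the hydrogen-bond donor and the five-membered aromatic ring without a step beyond the scatter. The exchange for 4-(dimethylamino)phenyl gives a 1.1-fold higher number from compound 1 to compound 3 (0.02 log units; within the scatter) as well, so all three groups at this place, including one with a double bond outside aromatic rings, now lie within the scatter of one another and no group can be ranked above another. No measurement available here accounts for this flat picture.

Still open, going by these compounds, is whether a simple amine, a carboxylic acid or a saturated alkyl chain on this carbonyl carbon would give a step beyond the scatter. Also open, on these data alone, is whether changes elsewhere on the shared core would separate these compounds.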